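Halogen swap on the pendant aryl of a piperidine series

This account rests on a few compounds, and the source may have more. Where it says the series, first, only, none or still open, it means among the compounds named here.

Measured so far:
compound 1 `CC(=O)Nc1cccc(C2CCN(CCCn3c(-c4ccccc4)nc4ccccc43)CC2)c1` — 2 nM
compound 2 `CC(=O)Nc1cccc(C2CCN(CCCn3c(-c4ccc(Cl)cc4F)nc4ccccc43)CC2)c1` — 1 nM

In an assay for displacement of a labelled ligand from melanin-concentrating hormone receptor 1 (Homo sapiens), read by fluorescence (on this read-out lower numbers stand for stronger inhibition and higher numbers for weaker inhibition), compound 2 gives the lowest of the two numbers; its nearest neighbour is compound 1, and the step of a 2.0-fold lower number from compound 1 to compound 2 (0.30 log units; within the scatter) stays inside the scatter. Compound 3 `CC(=O)Nc1cccc(C2CCN(CCCn3c(-c4ccc(F)cc4Cl)nc4ccccc43)CC2)c1` keeps the same atoms joined differently: 2-chloro-4-fluorophenyl in place of 4-chloro-2-fluorophenyl on an aromatic carbon, on an aromatic carbon of a five-membered aromatic ring with 2 nitrogen, part of a fused or bridged system of two rings. For the measured compounds named here, the only step that bears on this change is a 2.0-fold lower number from compound 1 to compound 2 (0.30 log units; within the scatter), and it shows that the halogen pattern on this ring barely moved this assay. No step beyond the scatter is therefore expected: a 1.5-fold higher number from compound 2 to compound 3 (0.18 log units; within the scatter). Compound 3 is estimated at 1.5 nM, with a range from 0.5 nM to 5 nM.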

Compound 3, half-maximal inhibitory concentration: 4 nM
Estimate against measurement, compound 3: 2.7-fold (0.43 log units) below, and the stated range covers the measured number.
By their numbers in this assay, from the lowest: compounds 2, 1 and 3 (each within the scatter of the next, the first and the last beyond it).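

With a 4.0-fold higher number from compound 2 to compound 3 (0.60 log units; beyond the scatter) as the step, the arrangement of the two halogens on this ring is not neutral, which the earlier pair could not show. Against plain phenyl, a 2.0-fold higher number from compound 1 to compound 3 (0.30 log units; within the scatter) stays inside the scatter, so the two halogenated rings part from each other without either parting from phenyl. Nothing available here gives a reason for that gap. On these data alone, whether chlorine or fluorine alone carries the step stays open, as does the outcome with a methoxy or trifluoromethyl group on this ring.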